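Solubility after swapping dimethylamino for piperidin-1-yl

The compounds below may be only part of what the source reports. "The series", "measured", "known", "first", "only" and "open" are said of these compounds alone.

Measured so far in a physicochemical assay for solubility, at pH 7.4; on this read-out lower numbers stand for lower solubility and higher numbers for higher solubility
- Compound 1 `CCCCNc1nc(N)c2nc(O)n(Cc3ccc(OC)nc3)c2n1` gives < 1000 ug/mL (a limit of the assay, not a number)
- Compound 2 `CCCCNc1nc(N)c2[nH]c(=O)n(Cc3ccc(N(C)C)cc3)c2n1` gives 98000 ug/mL

Among the compounds with values here, compound 2 gives 98000 ug/mL in this assay and this is the only exact number so far. Compound 1 offers only a limit, with no exact number to compare.

The next compound, compound 3 `CCCCNc1nc(N)c2[nH]c(=O)n(Cc3ccc(N4CCCCC4)cc3)c2n1`, differs from compound 2 in one place: piperidin-1-yl in place of dimethylamino on an aromatic carbon. It carries piperidin-1-yl in place of dimethylamino on an aromatic carbon.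

Within the data shown here, no step between two measured compounds shows what such a swap does, so the expectation rests on the structures alone and stays loose. A moderate fall in this assay seems more likely than a rise, though a change within the scatter remains possible. The expected size of the move is a 3.3-fold lower number from compound 2 to compound 3 (0.51 log units; beyond the scatter). For compound 3 the estimated value is 30000 ug/mL, with an expected range from 5000 ug/mL to 110000 ug/mL.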

Compound 3, solubility: 19000 ug/mL
The estimate for compound 3 lay 1.6-fold (0.20 log units) above the measured number, and the stated range covers the measured number.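

In this assay, within the data shown here, this is the first step that can be read: piperidin-1-yl in place of dimethylamino, on an aromatic carbon para to a large group, gives a 5.2-fold lower number from compound 2 to compound 3 (0.71 log units; beyond the scatter). So the read-out responds to a change at this position, even though the attached nitrogen stays and the swap adds only carbon atoms, but nothing shown explains the fall. Among these compounds, compound 1 gives < 1000 ug/mL, a limit of the assay and not a number, so no step involving it can be read.

One step cannot separate the effect of closing a ring from that of adding carbon atoms. A pyrrolidin-1-yl or morpholin-4-yl group, or a plain primary amine, at the same position would test how far this single fall extends.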